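Compound 3 to compound 4: replacing the 4-methoxyphenyl

The source may hold more compounds than are shown below. What is called first, only, known or untested is meant among the compounds shown, and "the series" means these compounds.

In a functional assay on the whole organism with Canis familiaris (Canis lupus familiaris) as the target (a lower number here means that less compound is needed, a higher number that more compound is needed for the effect), compound 3 (`COc1ccc(Nc2ncnc3c2ncn3C2O[C@H](C(=O)O)[C@@H](O)[C@H]2O)cc1`) gives 2 nM, a value within the scatter of compound 1 (`CCNC(=O)[C@H]1OC(n2cnc3c(NC4CCCCC4)ncnc32)[C@H](O)[C@@H]1O`) at 1.6 nM. Compound 2 (`CNc1ncnc2c1ncn2C1O[C@H](C(=O)O)[C@@H](O)[C@H]1O`) gives 0.46 nM. For the measured compounds named here, the only measured step at this nitrogen, a 4.3-fold higher number from compound 2 to compound 3 (0.64 log units; beyond the scatter), is modest but beyond the scatter.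

Compound 4 (`O=C(O)[C@H]1OC(n2cnc3c(NC4CCCCC4)ncnc32)[C@H](O)[C@@H]1O`) has cyclohexyl in place of 4-methoxyphenyl on a nitrogen on an aromatic ring. Going by the values given here, no measured step covers this exchange directly. Compound 1, at 1.6 nM, already carries cyclohexylamino but differs elsewhere, so it offers only indirect support. The expected change is a 1.3-fold lower number from compound 3 to compound 4 (0.12 log units; within the scatter), which would stay within the scatter. Compound 4 is estimated at 1.5 nM, with an expected range of 0.5 nM to 5 nM.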

Compound 4, half-maximal effective concentration: 1.5 nM
The estimate for compound 4 equals the measured number at the digits printed, within the range that was stated.
By their numbers in this assay, from the lowest: compound 2; then compounds 4, 1 and 3 (each within the scatter of the next).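

In this assay, swapping the aromatic 4-methoxyphenyl for the non-aromatic cyclohexyl on this nitrogen makes no readable difference (a 1.3-fold lower number from compound 3 to compound 4 (0.12 log units; within the scatter)). Methyl stays apart from cyclohexyl as well (a 3.3-fold higher number from compound 2 to compound 4 (0.51 log units; beyond the scatter)), in the same direction as from 4-methoxyphenyl (a 4.3-fold higher number from compound 2 to compound 3 (0.64 log units; beyond the scatter)). With cyclohexylamino held fixed, exchanging ethylamino for hydroxy on the carbonyl carbon also leaves the number unchanged within the scatter (a 1.1-fold lower number from compound 1 to compound 4 (0.03 log units; within the scatter)). No evidence on the cause of these results is available. Open, from the compounds shown here alone, are a longer chain or a benzyl group on this nitrogen, and whether ethylamino and hydroxy on the carbonyl carbon also stay level when methyl sits on the nitrogen.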